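The source may report more compounds than this note shows. Statements on the series, on what has been measured and on what is new or still open speak of the compounds shown alone.

Three nucleoside analogues have been measured in a functional assay on HL-60 cells (Homo sapiens) for antiproliferative activity, read by XTT assay, with a stated time of 72 h; on this read-out lower numbers stand for stronger inhibition and higher numbers for weaker inhibition. Compound 1 `COc1ncnc2c1c(-c1ccsc1)cn2[C@@H]1O[C@H](CO)[C@@H](O)[C@H]1O` gives 130 nM. Compound 2 `COc1nc(N)nc2c1c(-c1ccccc1)cn2[C@@H]1O[C@H](CO)[C@@H](O)[C@H]1O` reaches only a limit of the assay, > 20000 nM, and no number. Compound 3 `Cc1nc(N)c2c(-c3ccccc3)cn([C@@H]3O[C@H](CO)[C@@H](O)[C@H]3O)c2n1` likewise stops at the limit of the assay, > 20000 nM. Compound 2 therefore stands at the weak end of what has been seen, and it shares that position with compound 3, as noted in the limit of > 20000 nM in this assay, at which 2 of the 3 values shown sit. No pair among these three differs in a single place, so no single step has been quantified.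

Compound 4 `COc1nc(N)nc2c1c(-c1cccs1)cn2[C@@H]1O[C@H](CO)[C@@H](O)[C@H]1O` is not yet measured in this assay. Its change from compound 2 is thiophen-2-yl in place of phenyl on an aromatic carbon. Compound 1, which carries a thiophene ring on the same part of the core, gives 130 nM, but it differs from compound 2 in more than one place, so its number alone does not tell the size of the thiophene swap. The step from compound 2 to compound 4 is expected to be small, within the usual scatter or at most a modest gain, an at least 1.6-fold lower number from compound 2 to compound 4 (0.22 log units; that floor lies within the scatter). Compound 4 is thus estimated at 12000 nM, with a plausible range from 2500 nM to 20000 nM.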

Compound 4, half-maximal inhibitory concentration: > 20000 nM
Compound 4 was reported as a limit; the forecaster's own chance of this, stated with the estimate: 55%; at least 1.6-fold (0.22 log units) between middle value and limit.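

Compound 2 and compound 4 both stop at a limit of the assay, so the size of the change from phenyl to thiophen-2-yl cannot be read: the limit of > 20000 nM in this assay, at which 3 of the 4 values shown sit.

The compounds shown leave open whether this swap changes activity at all, and which of compound 1's several differences from compound 4 goes with its measurable activity.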